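Methyl Added to Compound 3: Forecast for Compound 4

A few compounds are considered here, and "the series" means these few. Any claim that something is new, unique, unknown or untested is made for them only; others in the source may bear on it.

Measured compounds in a functional assay on the whole organism (strain Wistar) for inhibition, with Rattus norvegicus as the target, with stated times of 30 min and 2 h, at a dose of 20 mg/kg by the oral route; on this read-out higher numbers stand for more inhibition at the one dose given (going by the name of the read-out) and lower numbers for less inhibition:
compound 1 `O=C(CCc1nnc(-c2ccc([N+](=O)[O-])cc2)o1)c1ccccc1` gives 40.9%
compound 2 `COc1ccc(-c2nnc(CCC(=O)c3ccc(C)cc3)o2)cc1` gives 69.3%
compound 3 `COc1ccc(-c2nnc(CCC(=O)c3ccc(C)cc3)o2)cc1OC` gives 53.3%

Compound 3 stands second of the three, with compound 1 lower and compound 2 higher, both beyond the scatter. Compound 4 `COc1ccc(-c2nnc(CCC(=O)c3ccc(C)cc3C)o2)cc1OC` differs from compound 3 by methyl in place of hydrogen on an aromatic carbon. Among the compounds with values here, the one step recorded, a number 16 percentage points lower from compound 2 to compound 3 (beyond the scatter), concerns a methoxy group and a different ring, so it does not bear directly on a methyl entering; no measured step covers this change. With nothing to point either way, the expected step of a number 3.3 percentage points lower from compound 3 to compound 4 (within the scatter) is none beyond the scatter. Compound 4 is therefore estimated at 50%, with a range from 30% to 70%.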

Compound 4, a percentage reported as inhibition, in the whole organism at one dose (the size of the read-out at that dose, not a potency): 58.7%
Compound 4: the middle estimate sits 8.7 percentage points below what was measured; the range from low to high includes it.
By their numbers in this assay, from the lowest: compound 1; then compounds 3 and 4 (each within the scatter of the next); then compound 2.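

Taking 4-methylphenyl to 2,4-dimethylphenyl, with the methyl ortho to a large group, gives a number 5.4 percentage points higher from compound 3 to compound 4 (within the scatter) in this assay, the first reading at this position. Unlike the methoxy step on the other ring, a number 16 percentage points lower from compound 2 to compound 3 (beyond the scatter), this methyl step stays within the scatter, so the assay does not separate the two compounds. Nothing measured here accounts for this result.

From the compounds shown here alone, it remains open how a longer chain or an amine at this position would read. Also open, going by these compounds, is how the same methyl would read on compound 2, which has a single methoxy group.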